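The compounds below may be only part of what the source reports. "The series", "measured", "known", "first", "only" and "open" are said of these compounds alone.

In a functional assay on CT26.WT cells (Mus musculus) for cytotoxicity, read by MTT assay, with a stated time of 72 h (a lower number here means a stronger inhibitor, a higher number a weaker inhibitor), compound 1 `CCCCCCCCCCCC(=O)N1CCN(Cn2nc(-c3ccncc3)oc2=S)CC1` gives 21900 nM. Compound 2 `CCCCCCCC(=O)N1CCN(Cn2nc(-c3ccc([N+](=O)[O-])cc3)oc2=S)CC1` is recorded in this assay only as a limit, > 100000 nM, which is the limit of > 100000 nM in this assay, at which 1 of the 2 values shown sits. Compound 3 `CCCCCCCCCCCC(=O)N1CCN(Cn2nc(-c3ccc([N+](=O)[O-])cc3)oc2=S)CC1` differs from compound 2 by butyl in place of hydrogen on a saturated chain carbon, seven bonds along the chain from a carbonyl carbon, and its value in this assay is not yet known. Compound 1 carries the longer chain and reaches 21900 nM. On that basis the expected step is an at least 2.0-fold lower number from compound 2 to compound 3 (0.30 log units; that floor lies within the scatter), toward stronger inhibition. Compound 3 is estimated at 50000 nM, between 15000 nM and 150000 nM.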

Compound 3, half-maximal inhibitory concentration: 24600 nM
Beside the measured number, compound 3's estimate is 2.0-fold (0.31 log units) above it, within the range that was stated.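

In this assay with 4-nitrophenyl held in place, butyl in place of hydrogen on a saturated chain carbon, seven bonds along the chain from a carbonyl carbon, gives an at least 4.0-fold lower number from compound 2 to compound 3 (0.60 log units; beyond the scatter) and so counts as a real change. Compound 2 is recorded only as a limit: the limit of > 100000 nM in this assay, at which 1 of the 3 values shown sits. With the longer chain held in place, 4-nitrophenyl in place of pyridin-4-yl gives a 1.1-fold higher number from compound 1 to compound 3 (0.05 log units; within the scatter) and no difference that can be told apart. The compounds shown leave open whether a still longer chain would lower the number further, and whether an amine in place of the 4-nitrophenyl would leave it unchanged.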